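The source may report more compounds than this note shows. Statements on the series, on what has been measured and on what is new or still open speak of the compounds shown alone.

Working notes on the acid series. In a physicochemical assay for lipophilicity, at pH 7.4 (a lower number here means a more polar compound, a higher number a more lipophilic compound), compound 3 (`Cc1nn(-c2nnc(-c3ccc(OC(C)C)c(Cl)c3)s2)c(C)c1CC(=O)O`) gives 3.62. Compound 2 (`CC(C)Oc1ccc(-c2nnc(-n3ncc4c3CCN(CCC(=O)O)C4)s2)cc1Cl`) gives 3.54, within the scatter of compound 3. Compound 1 (`Cc1c2c(nn1-c1nnc(-c3ccc(OC(C)C)c(C#N)c3)s1)CCN(CCC(=O)O)C2`) gives 2.76, lower than compound 3 by more than the scatter.

Compound 4 (`Cc1nn(-c2nnc(-c3ccc(OC(C)C)c(Cl)c3)s2)c(C)c1CCC(=O)O`) has not yet been measured. It differs from compound 3 in one place: carboxymethyl in place of carboxy on a saturated chain carbon bound to an aromatic carbon. This puts carboxymethyl in place of carboxy on a saturated chain carbon bound to an aromatic carbon, and the same difference, cut one bond further out, reads carboxymethyl to 2-carboxyethyl. For the measured compounds named here, compound 1 and compound 2 also carry a 2-carboxyethyl, but neither differs from compound 3 in one place only, so no measured step isolates this change. The size of the step therefore remains an expectation with no direct support from the series.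

A small upward move is expected in this assay, near the edge of the scatter, and the estimate starts from compound 3 at 3.62. The expected step is a number 0.33 log units higher from compound 3 to compound 4 (beyond the scatter). For compound 4 the estimated value is 3.95, with an expected range of 3.6 to 4.3.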

Compound 4, distribution coefficient: 4.3
Estimate against measurement, compound 4: 0.35 log units below; the measured number falls inside the stated range.
By their numbers in this assay, from the lowest: compound 1; then compounds 2 and 3 (each within the scatter of the next); then compound 4.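

In this assay, for the compounds shown here, the change from carboxymethyl to 2-carboxyethyl, on a saturated chain carbon bound to an aromatic carbon, gives the only isolated step, a number 0.68 log units higher from compound 3 to compound 4 (beyond the scatter), and this size can now be attached to this one change on this core. The entering group differs from the leaving group by carbon alone, with its hydrogen-bond donor and acceptor counts unchanged, and compound 1 and compound 2, though they carry a 2-carboxyethyl, differ from compound 3 in more than one place and could not show this. No measurement shown here bears on why the number moves.

Going by these compounds, whether a step of this size holds on another core remains open: compound 1 and compound 2 have no carboxymethyl partner to read it against. A longer chain ending in a carboxylic acid, or an amine at this same place, lies outside the compounds shown, and one step cannot tell whether the number keeps moving as the chain grows.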